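A few compounds are considered here, and "the series" means these few. Any claim that something is new, unique, unknown or untested is made for them only; others in the source may bear on it.

Measured so far in a physicochemical assay for lipophilicity, read by HPLC, in phosphate buffer, measured as octanol-water partition, with a stated time of 1 h, at pH 7.4; a lower number here means a more polar compound, a higher number a more lipophilic compound:
- compound 1 `N#Cc1ccc(C(=O)Nc2ccc(F)c([C@]3(C4CC4)C=C(CF)OC(N)=N3)c2)nc1`: 2.9
- compound 2 `COCC1=C[C@@](C)(c2cc(NC(=O)c3ccc(C#N)cn3)ccc2F)N=C(N)O1`: 2
- compound 3 `C[C@@]1(c2cc(NC(=O)c3ncc(C#N)cc3Cl)ccc2F)C=C(CF)OC(N)=N1`: 2.5

Of these three, compound 3 holds the middle place at 2.5. Compound 1 reads higher and compound 2 reads lower, and both gaps lie beyond the usual scatter of repeated measurements.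

The compound still to be measured is compound 4 `C[C@@]1(c2cc(NC(=O)c3ncc(OCF)nc3N)ccc2F)C=C(CF)OC(N)=N1`. It carries 3-amino-5-(fluoromethoxy)pyrazin-2-yl in place of 3-chloro-5-cyanopyridin-2-yl on a carbonyl carbon. In full, the change reads: 3-amino-5-(fluoromethoxy)pyrazin-2-yl in place of 3-chloro-5-cyanopyridin-2-yl on a carbonyl carbon.

Among the compounds with values here, no two measured compounds differ in one place only, so the data hold no direct precedent for this exchange. The three measured compounds also differ from one another in more than one place, which leaves their spread as a rough guide only. The expectation therefore rests on the counted difference and on compound 3 at 2.5. Going by the hydrogen-bond donors and acceptors counted in that difference, a small move towards a lower number is expected, though none beyond the scatter. In this assay the expected change is a number 0.20 log units lower from compound 3 to compound 4 (within the scatter).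

For compound 4 the estimate is 2.3, with an expected range from 1.8 to 2.8.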

Compound 4, distribution coefficient: 3.1
For compound 4 the middle estimate is 0.80 log units below the measured one; measured number above the stated range.
By their numbers in this assay, from the lowest: compound 2; then compound 3; then compounds 1 and 4 (each within the scatter of the next).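

Within the data shown here, compound 3 and compound 4 form the first measured pair that differs in one place only, on a carbonyl carbon whose other neighbours are: amide-type nitrogen. In this assay, 3-amino-5-(fluoromethoxy)pyrazin-2-yl in place of 3-chloro-5-cyanopyridin-2-yl gives a number 0.60 log units higher from compound 3 to compound 4 (beyond the scatter), so the number at this place can rise beyond the scatter even though the entering group counts 1 hydrogen-bond donor and 4 hydrogen-bond acceptors, against 0 hydrogen-bond donors and 2 hydrogen-bond acceptors for the group that leaves. For this change, those counts did not give the direction of the step, and no measurement shown accounts for it.

This single exchange alters the ring and all its groups at once, so the compounds shown cannot assign the step to the amino group, the fluoromethoxy group, or the loss of the chlorine or the nitrile. As far as these compounds go, how this assay would read with an ethoxy group in place of the fluoromethoxy group, or a dimethylamino group in place of the amino group, also remains open.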